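Ester aryl placement in a tetrazole-bearing imidazole series

The compounds below may be only part of what the source reports. "The series", "measured", "known", "first", "only" and "open" are said of these compounds alone.

Compound 1 `CCCc1nc(CC)c(C(=O)OCc2ccccc2-c2ccccc2)n1Cc1ccc(-c2ccccc2-c2nn[nH]n2)cc1` is the reference here. For the measured compounds named here, in an assay on isolated protein for binding affinity to Type-2 angiotensin II receptor (Homo sapiens) (on this read-out higher numbers stand for weaker inhibition and lower numbers for stronger inhibition), compound 1 gives 2000 nM, the highest of the three numbers so far. Compound 2 `CCCc1nc(CC)c(C(=O)OCc2ccccc2C(=O)c2ccccc2)n1Cc1ccc(-c2ccccc2S(=O)(=O)NC(=O)OCCc2ccccc2)cc1` gives 2.1 nM and compound 3 `CCCc1nc(CC)c(C(=O)OCC(=O)c2ccccc2)n1Cc1ccc(-c2ccccc2S(=O)(=O)NC(=O)OCCC(C)C)cc1F` gives 2 nM; both sit far below compound 1, beyond the scatter, with compound 2 nearest and compound 3 furthest. Both of these carry a different acid group and a different ester, so none of these pairs forms a single-point step.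

Compound 4 `CCCc1nc(CC)c(C(=O)OCc2ccc(-c3ccccc3)cc2)n1Cc1ccc(-c2ccccc2-c2nn[nH]n2)cc1` differs from compound 1 in one place: 4-phenylphenyl in place of 2-phenylphenyl on a saturated chain carbon bound to an oxygen next to a carbonyl group. Going by the values given here, no measured pair isolates this rearrangement of the same atoms. Among the compounds with values here, compounds 2 and 3 both keep a second aromatic unit close to the ester carbon, as compound 1 does, and neither moves it outward, so the change in compound 4 has no precedent in the set. The expected step from compound 1 to compound 4 is a 2.0-fold higher number from compound 1 to compound 4 (0.30 log units; within the scatter), a small move toward weaker binding that may not exceed the scatter. For compound 4 in this assay the estimate is 4000 nM, with a range from 1000 nM to 20000 nM.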

Compound 4, half-maximal inhibitory concentration: 3000 nM
The estimate for compound 4 lay 1.3-fold (0.12 log units) above the measured number; measured number inside the range.
By their numbers in this assay, from the lowest: compounds 3 and 2 (each within the scatter of the next); then compounds 1 and 4 (each within the scatter of the next).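

In this assay, the change to 4-phenylphenyl in place of 2-phenylphenyl on a saturated chain carbon bound to an oxygen next to a carbonyl group gives a 1.5-fold higher number from compound 1 to compound 4 (0.18 log units; within the scatter). For the compounds shown here, with the same atoms joined differently, this read-out therefore does not separate the two arrangements of the aryl groups, a comparison that the earlier compounds could not provide. No supporting data bear on the reason for this result.

On these data alone, whether a naphthyl group or a longer chain carrying a phenyl group at this place would also stay within the scatter of compound 1 remains open. As far as these compounds go, compounds 2 and 3 differ from compound 1 in more than one place, so it is also open whether this step would hold with their acid groups.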